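Phenyl for trimethoxyphenyl: the step to compound 4

The compounds below may be only part of what the source reports. "The series", "measured", "known", "first", "only" and "open" are said of these compounds alone.

Compound 1 `COc1ccccc1/C=C/C(=O)/C=C/c1ccc(OCc2cn(CCOc3cc(=O)oc4ccccc34)nn2)c(OC)c1`: 70%
Compound 2 `COc1ccccc1/C=C/C(=O)/C=C/c1ccc(OCc2cn(CCCCOc3cc(=O)oc4ccccc34)nn2)c(OC)c1`: 43%
Compound 3 `COc1cc(/C=C/C(=O)/C=C/c2cc(OC)c(OC)c(OC)c2)ccc1OCc1cn(CCCCCOc2cc(=O)oc3ccccc23)nn1`: 53%

Of the compounds shown here, three have been measured in a functional assay on HCT-116 cells (Homo sapiens) for inhibition, read by sulforhodamine B assay, with a stated time of 48 h, tested at 50 uM; on this read-out lower numbers stand for less inhibition of growth and higher numbers for more inhibition of growth at the one concentration tested. Compound 3 stands second highest of the three numbers; its nearest neighbour is compound 2, whose value lies within the scatter of that of compound 3, while compound 1 lies beyond the scatter above it. Compound 4 `COc1cc(/C=C/C(=O)/C=C/c2ccccc2)ccc1OCc1cn(CCCCCOc2cc(=O)oc3ccccc23)nn1` differs from compound 3 in one place: phenyl in place of 3,4,5-trimethoxyphenyl on a double-bonded chain carbon bound to a double-bonded chain carbon. Going by the values given here, no step between measured compounds covers this change, so the size of the step in this assay can only be guessed; a modest fall, or none beyond the scatter, is expected. Compound 4 is expected to reach about 45% in this assay, within a range from 25% to 65%. The expected step of a number 8 percentage points lower from compound 3 to compound 4 (within the scatter) would thus be a small fall.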

Compound 4, percent growth inhibition at one concentration: 24%
Estimate against measurement, compound 4: 21 percentage points above; measured number outside the range, below it.
By their numbers in this assay, from the lowest: compound 4; then compounds 2 and 3 (each within the scatter of the next); then compound 1.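

In this assay, replacing 3,4,5-trimethoxyphenyl with phenyl gives a number 29 percentage points lower from compound 3 to compound 4 (beyond the scatter), so this position on a double-bonded chain carbon bound to a double-bonded chain carbon clearly affects growth inhibition at the one concentration tested. Going by these compounds alone, this rests on a single pair with the same chain and the same remaining structure, and the earlier compounds offered no such comparison. No measurement of any property bears on this result. On these data alone, it remains open whether a phenyl carrying an amine or a carboxylic acid would restore inhibition at this position. As far as these compounds go, the same change on a shorter chain also remains open.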